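Cinnamamide anilinoquinazolines: trimethoxyphenyl to bromophenyl on the acrylamide

The source may report more compounds than this note shows. Statements on the series, on what has been measured and on what is new or still open speak of the compounds shown alone.

Compound 1 `COc1cc(/C=C/C(=O)Nc2cc3c(Nc4ccc(F)c(Cl)c4)ncnc3cc2O[C@H]2CCOC2)cc(OC)c1OC` is the reference of the series. In a functional assay on PC-3 cells (Homo sapiens) for cytotoxicity, read by MTT assay, with a stated time of 72 h (a higher number here means a weaker inhibitor, a lower number a stronger inhibitor), compound 1 gives 20500 nM, the lowest of the two numbers measured. Its nearest neighbour is compound 3 `COc1cc2ncnc(Nc3ccc(F)c(Cl)c3)c2cc1NC(=O)/C=C/c1cc(OC)c(OC)c(OC)c1`, which in this assay gives 38200 nM; the step of a 1.9-fold higher number from compound 1 to compound 3 (0.27 log units; within the scatter) shows that exchanging the ether on the core barely moves the number. Compound 2 `COc1ccc(/C=C/C(=O)Nc2cc3c(Nc4ccc(F)c(Cl)c4)ncnc3cc2OC)cc1` is recorded in this assay as "not active" (no number reported), without a number.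

Compound 4 `O=C(/C=C/c1ccc(Br)cc1)Nc1cc2c(Nc3ccc(F)c(Cl)c3)ncnc2cc1O[C@H]1CCOC1` keeps the oxolan-3-yl ether of compound 1 and changes the aryl on the acrylamide: 4-bromophenyl in place of 3,4,5-trimethoxyphenyl on a double-bonded chain carbon bound to a double-bonded chain carbon.

Among the measured compounds shown here, no measured step touches this position, so the single-change steps give no direct guide. For the measured compounds named here, compound 2, the only compound without the 3,4,5-trimethoxyphenyl, reports no number in this assay, which leans the expectation toward a weaker inhibitor. Compound 4 is therefore expected at 45000 nM, within 15000 nM to 150000 nM, i.e. an expected step of a 2.2-fold higher number from compound 1 to compound 4 (0.34 log units; beyond the scatter), with a real chance that only a limit is reported.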

Compound 4, half-maximal inhibitory concentration: 28200 nM
Compound 4: middle estimate off by 1.6-fold (0.20 log units), on the high side, within the range that was stated.
By their numbers in this assay, from the lowest: compounds 1, 4 and 3 (each within the scatter of the next).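

At the place on a double-bonded chain carbon bound to a double-bonded chain carbon, 4-bromophenyl in place of 3,4,5-trimethoxyphenyl gives a 1.4-fold higher number from compound 1 to compound 4 (0.14 log units; within the scatter) in this assay, so with the oxolan-3-yl ether held fixed, this exchange of aryl groups is not resolved from the reference. The 3,4,5-trimethoxyphenyl group is therefore not needed for a numerical reading with this ether: compound 4 still gives a number, with 0 hydrogen-bond acceptors in the entering group against 3 in the group that leaves. No evidence at hand bears on this result.

From the compounds shown here alone, whether a dimethylamino group or a carboxylic acid on this aryl ring would move the number beyond the scatter stays open. Also open, going by these compounds, is how 4-bromophenyl reads with the methyl ether of compound 3 on the shared core.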